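The source may hold more compounds than are shown below. What is called first, only, known or untested is meant among the compounds shown, and "the series" means these compounds.

Measured so far in an assay on isolated protein for binding affinity to Equilibrative nucleoside transporter 1 (Homo sapiens); a lower number here means a stronger inhibitor, a higher number a weaker inhibitor:
- compound 1, `O=[N+]([O-])c1ccc(O)c(CSc2ncnc3c2ncn3[C@@H]2O[C@H](CO)[C@@H](O)[C@H]2O)c1`: 33.1 nM
- compound 2, `CC(C)c1ccc(CSc2ncnc3c2ncn3[C@@H]2O[C@H](CO)[C@@H](O)[C@H]2O)cc1`: 4790 nM
- compound 3, `Cc1cccc(CSc2ncnc3c2ncn3[C@@H]2O[C@H](CO)[C@@H](O)[C@H]2O)c1`: 12000 nM

Compound 3 gives the highest number of the three in this assay. Its nearest neighbour is compound 2, with a 2.5-fold higher number from compound 2 to compound 3 (0.40 log units; beyond the scatter) between them, a modest step; the far end is compound 1, with a 360-fold higher number from compound 1 to compound 3 (2.56 log units; beyond the scatter), a large step. The other large step is a 140-fold higher number from compound 1 to compound 2 (2.16 log units; beyond the scatter).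

Compound 4, `OC[C@H]1O[C@@H](n2cnc3c(CSc4cccc(Br)c4)ncnc32)[C@H](O)[C@@H]1O`, is not yet measured. Its change from compound 3 is ((3-bromophenyl)sulfanyl)methyl in place of (3-methylbenzyl)sulfanyl on an aromatic carbon. The ring substitution keeps the 3 position, with bromine replacing methyl, while the order of sulfur and the saturated chain carbon between the ring and the shared core is reversed.

Within the data shown here, none of the measured steps touches this kind of change: all three steps swap one aryl ring for another on the same (aryl-methyl)sulfanyl arrangement. Among the measured compounds shown here, the only comparison among the simpler rings, compound 2 to compound 3, was modest, so a change of the same weight is plausible here, but the reversed linker has no precedent and the direction is open. The expected step is a 1.5-fold lower number from compound 3 to compound 4 (0.18 log units; within the scatter), with wide bounds.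

Compound 4 is estimated at 8000 nM in this assay, with an expected range of 2000 nM to 40000 nM.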

Compound 4, half-maximal inhibitory concentration: 363 nM
For compound 4 the middle estimate is 22-fold (1.34 log units) above the measured one; measured number below the stated range.
By their numbers in this assay, from the lowest: compound 1; then compound 4; then compound 2; then compound 3.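

In this assay the swap of (3-methylbenzyl)sulfanyl for ((3-bromophenyl)sulfanyl)methyl gives a 33-fold lower number from compound 3 to compound 4 (1.52 log units; beyond the scatter) and shows that this aromatic carbon can carry a large change in the number without the 2-hydroxy-5-nitrophenyl ring of compound 1. The reversed order, with the saturated chain carbon on the shared core and the sulfur on the ring, is therefore compatible with a stronger result, and compound 4 now has the second-lowest number of the four, after compound 1 alone. Nothing available accounts for the size of this step.

The step combines the reversed linker with bromine in place of methyl, so the contribution of each cannot be separated: that would take 3-methylphenyl on the reversed linker, or 3-bromophenyl on the original (aryl-methyl)sulfanyl arrangement. Also open, going by these compounds, is how a longer chain in place of the saturated chain carbon, or an amine or a carboxylic acid in place of the bromine, would read in this assay on this reversed linker.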